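Amine for hydroxyl on the sulfur-linked chain

This account rests on a few compounds, and the source may have more. Where it says the series, first, only, none or still open, it means among the compounds named here.

Compound 1 `CC(C)c1n[nH]c2c(NCc3ccc(-c4ccccn4)cc3)nc(SCCO)nc12` was tested in a functional assay on HT cells (Homo sapiens) for antiproliferative activity, read by fluorescence, with a stated time of 72 h (a higher number here means a weaker inhibitor of growth, a lower number a stronger inhibitor of growth), and gave 48 nM. Compound 2 `CC(C)c1n[nH]c2c(NCc3ccc(-c4ccccn4)cc3)nc(SCC(N)=O)nc12` in this assay gave 192 nM. Among the compounds with values here, of the two numbers so far, compound 1 holds the lowest; its nearest neighbour is compound 2, reached by a 4.0-fold higher number from compound 1 to compound 2 (0.60 log units; beyond the scatter), the only measured change on this chain, carbamoyl in place of hydroxymethyl on a saturated chain carbon bound to a sulfur.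

Compound 3 `CNCCSc1nc(NCc2ccc(-c3ccccn3)cc2)c2[nH]nc(C(C)C)c2n1` awaits measurement. It differs from compound 1 by methylamino in place of hydroxy on a saturated chain carbon, two bonds along the chain from a sulfur. Within the data shown here, the one step that bears on it, a 4.0-fold higher number from compound 1 to compound 2 (0.60 log units; beyond the scatter), shows a change at this end of the chain costing a modest amount; it says nothing directly about methylamino. A small loss or none beyond the scatter is expected, written as a 1.6-fold higher number from compound 1 to compound 3 (0.19 log units; within the scatter). Compound 3 is therefore estimated at 75 nM in this assay, with a range from 25 nM to 220 nM.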

Compound 3, concentration for 50% growth inhibition: 56 nM
For compound 3 the middle estimate is 1.3-fold (0.13 log units) above the measured one; measured number inside the range.
By their numbers in this assay, from the lowest: compounds 1 and 3 (each within the scatter of the next); then compound 2.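

In this assay the step for methylamino in place of hydroxy on a saturated chain carbon, two bonds along the chain from a sulfur, is a 1.2-fold higher number from compound 1 to compound 3 (0.07 log units; within the scatter) and so shows no change in growth inhibition. The cost seen with compound 2 is therefore not shared by every replacement at this end of the chain. Going the other way, (methylamino)methyl in place of carbamoyl gives a 3.4-fold lower number from compound 2 to compound 3 (0.54 log units; beyond the scatter) and leaves compound 2 as the one of the three that stands apart.

A primary amine, a dimethylamino group, a carboxylic acid or a longer chain at this end lies outside the compounds shown, so how far this tolerance extends stays open. Nothing available explains why the carbamoyl compound differs from the other two.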